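A few compounds are considered here, and "the series" means these few. Any claim that something is new, unique, unknown or untested is made for them only; others in the source may bear on it.

The study gathers three quinazolinone-type compounds that share one core and differ in the group attached to the tetrazole nitrogen and in the aryl ring next to the amine. Compound 1 `CC1(c2ccc(NC(c3ccncc3)c3nnnn3C(C)(C)C)cc2)NC(=O)c2ccccc2N1` carries a pyridyl ring there; in an ADME assay on J774.A1 cells (Mus musculus) for cytotoxicity, read by MTT assay, with a stated time of 72 h (on this read-out lower numbers stand for higher toxicity in this test and higher numbers for lower toxicity in this test), compound 1 gives "not determined" (no result reported). Compound 3 `COc1cc(C(Nc2ccc(C3(C)NC(=O)c4ccccc4N3)cc2)c2nnnn2C(C)(C)C)cc(OC)c1OC` carries a trimethoxyphenyl ring; in this assay compound 3 gives "not determined" (no result reported). Compound 2 `CC1(c2ccc(NC(c3ccc(Cl)cc3)c3nnnn3C(C)(C)C)cc2)NC(=O)c2ccccc2N1` carries a chlorophenyl ring and a tert-butyl on the tetrazole. In this assay compound 2 shows only a limit, > 400000 nM, not a number. It is the sole entry with any figure, sitting at the limit of > 400000 nM in this assay, at which 1 of the 3 values shown sits, so nothing can be said about steps between measured compounds.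

Compound 4 `CC1(c2ccc(NC(c3ccc(Cl)cc3)c3nnnn3C3CCCCC3)cc2)NC(=O)c2ccccc2N1` is the next compound to be tested. It differs from compound 2 in one place: cyclohexyl in place of tert-butyl on an aromatic nitrogen. The change is the replacement of a tert-butyl by a cyclohexyl on the aromatic nitrogen of the tetrazole ring; the aryl ring and the rest of the core are unchanged.

Among the compounds with values here, with no measured step to lean on, the expectation for compound 4 in this assay rests on compound 2 alone. The expected move from compound 2 to compound 4, a number no higher from compound 2 to compound 4 (the limit leaves the size open), is none beyond the ordinary scatter. Compound 4 is therefore estimated at 400000 nM, within a range from 100000 nM to 1000000 nM, and it may well again appear only as a limit.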

Compound 4, half-maximal cytotoxic concentration: > 400000 nM
Compound 4 ended at the assay's limit; the forecaster's own chance of this, stated with the estimate: 70%; the middle value lies on the limit itself.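

In this assay compound 2 and compound 4 each appear only as a limit of the assay, not as a number, so no step can be read between these two compounds: the limit of > 400000 nM in this assay, at which 2 of the 4 values shown sit.

The compounds shown leave open whether cyclohexyl in place of tert-butyl changes this read-out at all, and by how much.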